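The compounds below may be only part of what the source reports. "The series", "measured", "known", "first", "only" and "open" are said of these compounds alone.

In an ADME assay on liver for metabolic stability, with Liver microsome (Homo sapiens) as the target, using microsomes (on this read-out lower numbers stand for slow clearance and higher numbers for fast clearance), compound 1 `COc1ccc(C(=O)Nc2[nH]nc(-c3ccccn3)c2C2CC2)cc1` gives 12.8 mL.min-1.g-1, compound 2 `O=C(Nc1cc(-c2ccccn2)n[nH]1)N1CCC(c2cccc(F)c2)CC1` gives 25.3 mL.min-1.g-1 and compound 3 `N#Cc1ccc(OC2CCN(C(=O)Nc3cc(-c4ccccn4)n[nH]3)CC2)cc1` gives 14.7 mL.min-1.g-1, so compound 3 sits within the scatter of both others. Compound 4 `O=C(Nc1cc(-c2ccccn2)n[nH]1)N1CCC(c2ccc(Cl)cc2)CC1` has 4-chlorophenyl in place of 4-cyanophenoxy on a saturated ring carbon. For the measured compounds named here, one measured step bears on this change at the same place: a 1.7-fold lower number from compound 2 to compound 3 (0.24 log units; within the scatter), where 4-cyanophenoxy took the place of 3-fluorophenyl. Going by the values given here, that step stays within the scatter, and no chlorophenyl example has been measured, so no step beyond the scatter is expected, with a lean toward the number of compound 2. The expected change is a 1.5-fold higher number from compound 3 to compound 4 (0.18 log units; within the scatter). For compound 4 the estimated value is 22 mL.min-1.g-1, with an expected range of 11 mL.min-1.g-1 to 42 mL.min-1.g-1.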

Compound 4, intrinsic clearance in microsomes: 30 mL.min-1.g-1
Compound 4: middle estimate off by 1.4-fold (0.13 log units), on the low side; the range from low to high includes it.
By their numbers in this assay, from the lowest: compounds 1, 3, 2 and 4 (each within the scatter of the next, the first and the last beyond it).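

In this assay, for the compounds shown here, this change on the saturated ring carbon gives the first step beyond the scatter, though a modest one (a 2.0-fold higher number from compound 3 to compound 4 (0.31 log units; beyond the scatter)). Exchanging 3-fluorophenyl for 4-chlorophenyl leaves the two compounds within the scatter (a 1.2-fold higher number from compound 2 to compound 4 (0.07 log units; within the scatter)), so the present data do not separate these two groups. No measurement on hand explains the step from 4-cyanophenoxy to 4-chlorophenyl. Still open, from the compounds shown here alone, is how 4-chlorophenoxy would compare, which would set the ether oxygen apart from the nitrile. An amine or a carboxylic acid on this ring carbon also remains untested in the compounds shown.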